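A few compounds are considered here, and "the series" means these few. Any claim that something is new, unique, unknown or untested is made for them only; others in the source may bear on it.

Measured in a functional assay on the whole organism (strain Swiss) with Mus musculus as the target, in the maximal electroshock model, with a stated time of 0.25 h, at a dose of 100 mg/kg by the intraperitoneal route; on this read-out higher numbers stand for a stronger effect at the one dose given and lower numbers for a weaker effect:
compound 1 `CCC(C(=O)N1CCN(c2cccc(Cl)c2)CC1)N1C(=O)CCC1=O`, 50%
compound 2 `CCC(C(=O)N1CCN(c2ccccc2F)CC1)N1C(=O)CCC1=O`, 0%
compound 3 `CC(C(=O)N1CCN(c2ccc(F)cc2)CC1)N1C(=O)CCC1=O`, 75%

Compound 3 gives the highest of the three numbers; compound 1 sits nearest to it and compound 2 furthest, both gaps beyond the scatter. Compound 4 `Cc1cccc(N2CCN(C(=O)C(C)N3C(=O)CCC3=O)CC2)c1` differs from compound 3 in one place: 3-methylphenyl in place of 4-fluorophenyl on an amine nitrogen in a ring. Among the compounds with values here, the only measured step that touches the group on the ring nitrogen is a number 50 percentage points lower from compound 1 to compound 2 (beyond the scatter), a large drop on exchanging one aryl for another at that position. Within the data shown here, no step with 3-methylphenyl is measured, and compound 3 differs from compound 1 in more than one place, so no direct guide exists. An aryl exchange at this nitrogen can therefore move this assay by a large amount, with the direction uncertain. A moderate downward step is expected, a number 20 percentage points lower from compound 3 to compound 4 (beyond the scatter). For compound 4 the estimate is 55%, range 20% to 90%.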

Compound 4, a percentage reported as activity, at one dose (the size of the read-out at that dose, not a potency): 0%
For compound 4 the middle estimate is 55 percentage points above the measured one; measured number below the stated range.
By their numbers in this assay, from the lowest: compounds 2 and 4 (each within the scatter of the next); then compound 1; then compound 3.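

In this assay, the aryl group on the amine nitrogen in a ring decides the read-out on the core of compound 3 as well: 3-methylphenyl in place of 4-fluorophenyl gives a number 75 percentage points lower from compound 3 to compound 4 (beyond the scatter). The two groups have equal heavy-atom counts and equal counts of hydrogen-bond donors and acceptors, so these counts do not separate them. No measurement at hand accounts for the drop.

Open, on these data alone, is whether the drop follows the methyl group or its ring position. A 4-methylphenyl or a 3-fluorophenyl group on the core of compound 3 would separate the two.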